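Swapping chloro for methyl on the benzoyl ring

The source may report more compounds than this note shows. Statements on the series, on what has been measured and on what is new or still open speak of the compounds shown alone.

Compound 2 `O=C(NC(=S)N1CCc2c(OCCCCCOc3ccc(Cl)cc3)cccc21)c1ccc(Cl)cc1` and compound 1 `O=C(NC(=S)N1CCc2c(OCCCCCOc3ccc(Cl)cc3)cccc21)c1cccc([N+](=O)[O-])c1` share one core and differ only in the aromatic ring attached to the carbonyl. In an ADME assay on Huh-7 cells (Homo sapiens) for cytotoxicity (a lower number here means that less compound is tolerated, a higher number that more compound is tolerated), compound 1 gives 12100 nM, and compound 2 gives 21700 nM, the higher of the two numbers, though the change a 1.8-fold higher number from compound 1 to compound 2 (0.25 log units; within the scatter) lies within the scatter. Compound 3 `Cc1ccc(C(=O)NC(=S)N2CCc3c(OCCCCCOc4ccc(Cl)cc4)cccc32)cc1` carries methyl in place of chloro on an aromatic carbon. Among the measured compounds shown here, only that one step bears on this change, and it was small, so no step beyond the scatter is expected, a 1.1-fold lower number from compound 2 to compound 3 (0.04 log units; within the scatter). Compound 3 is therefore estimated at 20000 nM, between 8000 nM and 50000 nM.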

Compound 3, half-maximal cytotoxic concentration: > 50000 nM
Compound 3: a limit, no number; the forecaster's own chance of this, stated with the estimate: 10%; middle value at least 2.5-fold (0.39 log units) from the limit.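

In this assay, swapping chloro for methyl at this place on the aromatic ring moves the number beyond the scatter, giving an at least 2.3-fold higher number from compound 2 to compound 3 (0.36 log units; beyond the scatter), whereas the earlier change of ring stayed within it. Set against the 3-nitrophenyl ring, the 4-methylphenyl ring gives an at least 4.1-fold higher number from compound 1 to compound 3 (0.61 log units; beyond the scatter). Compound 3 gives > 50000 nM, a limit of the assay and not a number: the limit of > 50000 nM in this assay, at which 1 of the 3 values shown sits.

On these data alone, how far compound 3 truly lies past that limit stays unknown. As far as these compounds go, whether an ethyl group, a methoxy group or an amine at this place would match methyl also remains open.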